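A few compounds are considered here, and "the series" means these few. Any claim that something is new, unique, unknown or untested is made for them only; others in the source may bear on it.

Measured in a functional assay on BGC-823 cells (Homo sapiens) for inhibition, read by MTT assay, with a stated time of 72 h; a higher number here means a weaker inhibitor, a lower number a stronger inhibitor:
- Compound 1 `O=C1/C(=C\c2ccccc2)c2c(ncn2COCc2ccccc2)CCN1Cc1ccccc1`: 20400 nM
- Compound 2 `Cc1ccc(CN2CCc3ncn(COCc4ccccc4)c3/C(=C/c3ccccc3)C2=O)cc1`: 39100 nM

Within the data shown here, compound 2 stands level with compound 1, the only other measured compound, once the usual scatter of repeat measurements is allowed for. Compound 3 `O=C1/C(=C\c2ccccc2)c2c(ncn2COCc2ccccc2)CCN1Cc1ccc(F)cc1` has not yet been measured. It differs from compound 2 by fluoro in place of methyl on an aromatic carbon, which is fluoro in place of methyl on an aromatic carbon.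

Among the measured compounds shown here, the one measured step concerns that same aromatic carbon, where methyl takes the place of hydrogen: a 1.9-fold higher number from compound 1 to compound 2 (0.28 log units; within the scatter). For the measured compounds named here, with only this small step as a guide, the new swap is expected to give no step beyond the scatter in this assay, and the data point to no direction.

The estimate for compound 3 is 28000 nM, with an expected range of 12000 nM to 60000 nM. This estimate means an expected 1.4-fold lower number from compound 2 to compound 3 (0.15 log units; within the scatter).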

Compound 3, half-maximal inhibitory concentration: 72900 nM
Compound 3: middle estimate off by 2.6-fold (0.42 log units), on the low side, outside the stated range (above it).
By their numbers in this assay, from the lowest: compounds 1, 2 and 3 (each within the scatter of the next, the first and the last beyond it).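

In this assay, among these compounds, putting fluoro in place of hydrogen on this aromatic carbon gives a 3.6-fold higher number from compound 1 to compound 3 (0.55 log units; beyond the scatter) and is the first change at this position to reach beyond the scatter, though only modestly, and toward a weaker inhibitor. Fluoro in place of methyl gives a 1.9-fold higher number from compound 2 to compound 3 (0.27 log units; within the scatter) and so does not separate these two groups, which leaves compound 2 level with both of its neighbours while compound 1 and compound 3 stand apart. No measurement at hand offers an explanation for these numbers.

As far as these compounds go, the three compounds hold only hydrogen, methyl or fluoro at this spot, so what an amine, a methoxy group or a carboxylic acid would do here stays open. Whether the same swaps would give similar steps elsewhere on the shared core also remains unanswered.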